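Swapping the indole of compound 2 for 4-ethoxy-3-methoxyphenyl

The source may hold more compounds than are shown below. What is called first, only, known or untested is meant among the compounds shown, and "the series" means these compounds.

Measured in a functional assay on DU-145 cells (Homo sapiens) for inhibition, read by trypan blue exclusion, with a stated time of 96 h; a higher number here means a weaker inhibitor of growth, a lower number a stronger inhibitor of growth:
- compound 1 `Cc1ccc(/C=C(\C(=O)c2ccc(Cl)cc2)S(=O)(=O)Cc2ccc(F)cc2)s1`: 50000 nM
- compound 2 `O=C(/C(=C\c1c[nH]c2ccccc12)S(=O)(=O)Cc1ccc(F)cc1)c1ccc(Cl)cc1`: 50000 nM
- compound 3 `O=C(/C(=C\c1ccc(Cl)cc1)SCc1ccccc1Cl)c1ccc(Cl)cc1`: 12000 nM

In this assay, compound 2 at 50000 nM stands level with compound 1, and the two share the highest number of the three. Compound 3 gives 12000 nM, a lower number, and its gap to compound 2 lies beyond the scatter.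

The next entry is compound 4 `CCOc1ccc(/C=C(\C(=O)c2ccc(Cl)cc2)S(=O)(=O)Cc2ccc(F)cc2)cc1OC`, which departs from compound 2 as follows: 4-ethoxy-3-methoxyphenyl in place of 1H-indol-3-yl on a double-bonded chain carbon bound to a double-bonded chain carbon.

Within the data shown here, only one measured step bears on this place, and it shows no change at the digits printed from compound 1 to compound 2 (within the scatter). That is a single exchange, so it gives a weak guide, but it offers no sign that a new group here moves the number. Among the measured compounds shown here, compound 3 differs from compound 2 in more than one place and gives no step for this change. Compound 3 at 12000 nM shows only that lower numbers occur among these compounds, so the range is left wider on the low side.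

No step beyond the scatter is expected, and the estimated step is a 1.4-fold lower number from compound 2 to compound 4 (0.15 log units; within the scatter). For compound 4 the expected value is 35000 nM, with an estimated range from 8000 nM to 70000 nM.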

Compound 4, concentration for 50% growth inhibition: 50000 nM
Compound 4: middle estimate off by 1.4-fold (0.15 log units), on the low side; measured number inside the range.
By their numbers in this assay, from the lowest: compound 3; then compounds 1, 2 and 4 (each within the scatter of the next).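

In this assay, the place on a double-bonded chain carbon bound to a double-bonded chain carbon now has a second exchange behind it: the change of group reads no change at the digits printed from compound 2 to compound 4 (within the scatter) and the comparison with the thiophene compound reads no change at the digits printed from compound 1 to compound 4 (within the scatter), so 5-methylthiophen-2-yl, 1H-indol-3-yl and 4-ethoxy-3-methoxyphenyl are not separated here. Among these compounds, the earlier step covered only two of these groups, whereas this one also spans a change from 1 hydrogen-bond donor and 0 hydrogen-bond acceptors in 1H-indol-3-yl to 0 hydrogen-bond donors and 2 hydrogen-bond acceptors in 4-ethoxy-3-methoxyphenyl, along with a move from 9 to 11 heavy atoms and from two rings to one, and the number holds through all of it. No measurement available on these compounds accounts for this flat result.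

Compound 3 gives 12000 nM but differs from compound 2 in more than one place, so its lower number cannot be traced to any single change. From the compounds shown here alone, whether an amine, a carboxylic acid or a plain alkyl chain at this place would move the number remains open.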